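The compounds below may be only part of what the source reports. "The series", "measured", "known", "first", "only" and "open" are said of these compounds alone.

Going by the values given here, in an ADME assay on microsomes from liver (Homo sapiens) for metabolic stability (on this read-out lower numbers stand for a shorter-lived compound and higher numbers for a longer-lived compound), compound 2 `CC#C[C@@H](Cc1nnn[nH]1)c1ccc(OCc2ccc3scc(-c4cc(OCCOC)ccc4C)c3c2)cc1` gives 0.867 h, the highest of the three numbers so far. Compound 4 `CC#C[C@@H](Cc1nnn[nH]1)c1ccc(OCc2ccc3scc(-c4ccccc4C(F)(F)F)c3c2)cc1` carries 2-(trifluoromethyl)phenyl in place of 5-(2-methoxyethoxy)-2-methylphenyl on an aromatic carbon. Among the compounds with values here, no measured step makes this change. The only one, a 2.6-fold higher number from compound 1 to compound 3 (0.42 log units; beyond the scatter), is chloro in place of fluoro, between compound 1 `CC#C[C@@H](Cc1nnn[nH]1)c1ccc(OCc2ccc3sc(F)c(-c4ccccc4C)c3c2)cc1` and compound 3 `CC#C[C@@H](Cc1nnn[nH]1)c1ccc(OCc2ccc3sc(Cl)c(-c4ccccc4C)c3c2)cc1`, and it serves only as a loose gauge of size. Without the 5-(2-methoxyethoxy)-2-methylphenyl group, compound 1 gives 0.0667 h and compound 3 gives 0.175 h, so a lower number is expected, though the halogen in both clouds the comparison. The expected change is a 2.5-fold lower number from compound 2 to compound 4 (0.39 log units; beyond the scatter). For compound 4 the estimated value is 0.35 h, with an expected range of 0.12 h to 1 h.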

Compound 4, half-life: < 0.0667 h
Compound 4 ended at the assay's limit; the forecaster's own chance of this, stated with the estimate: 5%; middle value at least 5.2-fold (0.71 log units) away from the limit.
By their numbers in this assay, from the lowest: compound 1; then compound 3; then compound 2.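

On an aromatic carbon of a five-membered aromatic ring with 1 sulfur, 2-(trifluoromethyl)phenyl in place of 5-(2-methoxyethoxy)-2-methylphenyl gives, in this assay, an at least 12-fold lower number from compound 2 to compound 4 (1.11 log units; beyond the scatter). The aryl group at this place can therefore move the half-life by a large step. The reading of compound 4 is a limit of the assay and not a number: the limit of < 0.0667 h in this assay, at which 1 of the 4 values shown sits.

The compounds shown hold no pair separating the loss of the 2-methoxyethoxy chain from trifluoromethyl replacing methyl. Going by these compounds, how an amine or a carboxylic acid in place of that chain would read stays open.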